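A few compounds are considered here, and "the series" means these few. Any claim that something is new, unique, unknown or untested is made for them only; others in the source may bear on it.

Measured so far in the series:
- compound 1, `Cc1ccc([C@@H](C)Oc2cc3onc(CCC(=O)O)c3cc2Cl)nc1`: 1.59 nM
- compound 2, `C[C@@H](Oc1cc2onc(CCC(=O)O)c2cc1Cl)c1ccc(F)cn1`: 31.6 nM

Both numbers come from an assay on HEK293 cells for inhibition of kynurenine 3-monooxygenase (Homo sapiens), read by LC-MS, with a stated time of 20 h; a higher number here means a weaker inhibitor, a lower number a stronger inhibitor. Among the compounds with values here, compound 2 gives the highest of the two numbers; its nearest neighbour is compound 1, and the only measured step, a 20-fold higher number from compound 1 to compound 2 (1.30 log units; beyond the scatter), is the one that separates them, a fluoro in place of a methyl on an aromatic carbon.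

The next compound, compound 3, `C[C@@H](Oc1cc2onc(CCC(=O)O)c2cc1Cl)c1ccccn1`, takes the step on from compound 2: hydrogen in place of fluoro on an aromatic carbon, that is, 5-fluoropyridin-2-yl becomes pyridin-2-yl. The measured step of a 20-fold higher number from compound 1 to compound 2 (1.30 log units; beyond the scatter) bears on this only indirectly: it shows that the group on this carbon matters a great deal in this assay, but it compares methyl with fluoro, not fluoro with hydrogen. Within the data shown here, no measured pair shows what removing the fluoro does. Given the size of that step, a move of compound 3 in either direction is possible, and the expectation leans towards a somewhat lower number than compound 2, with wide uncertainty; the estimated step is a 1.6-fold lower number from compound 2 to compound 3 (0.20 log units; within the scatter).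

Compound 3 is therefore expected to give about 20 nM in this assay, within a range from 5 nM to 80 nM.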

Compound 3, half-maximal inhibitory concentration: 3.16 nM
Beside the measured number, compound 3's estimate is 6.3-fold (0.80 log units) above it, outside the stated range (below it).
By their numbers in this assay, from the lowest: compounds 1 and 3 (each within the scatter of the next); then compound 2.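

In this assay, the group on this aromatic carbon, para to a large group and two atoms from the ring nitrogen, now reads differently: taking away the fluoro of 5-fluoropyridin-2-yl to leave pyridin-2-yl gives a 10-fold lower number from compound 2 to compound 3 (1.00 log units; beyond the scatter), so the fluoro itself carries a clear cost in this series. Methyl and hydrogen on this carbon cannot be told apart, with a 2.0-fold higher number from compound 1 to compound 3 (0.30 log units; within the scatter). The earlier step, a 20-fold higher number from compound 1 to compound 2 (1.30 log units; beyond the scatter), fits this: of the three groups on this carbon, fluoro gives the highest number. Nothing available explains why the fluoro behaves differently from the other two groups at this carbon.

The compounds shown leave open whether this loss is unique to fluoro, or whether a chloro, methoxy or amine on the same carbon would fall with fluoro or stay with methyl and hydrogen. They also leave open whether the same difference between fluoro and hydrogen holds once the carboxylic acid of the shared core is replaced by an amide.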